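The source may report more compounds than this note shows. Statements on the series, on what has been measured and on what is new or still open speak of the compounds shown alone.

Compound 1 is `COC(=O)c1ccc(OCc2oc(-c3cccc(OC)c3)nc2C)cc1`. In an assay on cells for antagonist activity at vitamin D3 receptor (Homo sapiens), read by a luciferase reporter (a higher number here means a weaker inhibitor, a lower number a stronger inhibitor), compound 1 gives 8890 nM.
Compound 2 is `COc1cccc(-c2nc(C)c(COc3ccc(C(=O)O)cc3)o2)c1`. In this assay compound 2 gives > 80000 nM, which is a limit of the assay rather than a number.
Compound 3 is `COc1ccccc1-c1nc(C)c(COc2ccc(CC(=O)O)cc2)o1`. In this assay compound 3 gives > 80000 nM, again a limit of the assay and not a number.

Within the data shown here, only one measured step joins two compounds that differ in a single place: an at least 8.9-fold higher number from compound 1 to compound 2 (0.95 log units; beyond the scatter). Compound 3 therefore stands at the upper edge of what the assay can report, sharing that position with compound 2, as the limit of > 80000 nM in this assay, at which 2 of the 3 values shown sit, shows.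

Compound 4 is `COc1cccc(-c2nc(C)c(COc3ccc(CC(=O)O)cc3)o2)c1`. It differs from compound 3 by 3-methoxyphenyl in place of 2-methoxyphenyl on an aromatic carbon. Among the measured compounds shown here, no measured step covers this exchange; the step from compound 1 to compound 2 concerns the acid end and says nothing about where the methoxy group sits. What can be said is that compound 2, which carries the same 3-methoxyphenyl as compound 4, also sits at the limit, while compound 3 sits there too. With both neighbours at the limit, no movement beyond the scatter is expected from the change; compound 4 is estimated to remain at or near the limit, at 90000 nM with a range from 30000 nM to 250000 nM, an expected step that the limit leaves unreadable from compound 3 to compound 4.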

Compound 4, half-maximal inhibitory concentration in the vitamin D3 receptor assay: 27700 nM
Beside the measured number, compound 4's estimate is 3.2-fold (0.51 log units) above it; measured number outside the range, below it.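

In the vitamin D3 receptor assay, the exchange of 2-methoxyphenyl for 3-methoxyphenyl gives an at least 2.8-fold lower number from compound 3 to compound 4 (0.46 log units; beyond the scatter), the first sign that this position on the five-membered ring responds to where the methoxy group sits on the phenyl ring, while in a physicochemical assay for solubility, tested at 500 uM (on this read-out lower numbers stand for lower solubility and higher numbers for higher solubility), the same exchange gives a 1.1-fold lower number from compound 3 to compound 4 (0.03 log units; within the scatter). In the physicochemical assay compound 3 gives 436000 nM and compound 4 gives 410000 nM. The acid end matters as well: in the vitamin D3 receptor assay, carboxymethyl in place of carboxy gives an at least 2.8-fold lower number from compound 2 to compound 4 (0.46 log units; beyond the scatter), yet carboxymethyl in place of methoxycarbonyl still gives a 3.1-fold higher number from compound 1 to compound 4 (0.49 log units; beyond the scatter), so the acid compound 4 does not reach the number of the ester compound 1. In the vitamin D3 receptor assay compound 2 gives > 80000 nM, which is a limit of the assay and not a number. In the vitamin D3 receptor assay compound 3 gives > 80000 nM, which is also a limit of the assay and not a number. The first two steps in the vitamin D3 receptor assay can be read only as minimum sizes, because both of these compounds sit at that limit: the limit of > 80000 nM in the vitamin D3 receptor assay, at which 2 of the 4 values shown sit.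

As far as these compounds go, what a methyl ester on the carboxymethyl chain would give in place of the free acid stays open, as does a longer chain ending in a carboxylic acid or an amide at that end. Also open, from the compounds shown here alone, is how a chlorine or a hydroxyl group in place of the methoxy group on the phenyl ring would read.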